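From 3,5-dimethoxyphenyl to 3-cyanophenyl: what to expect

This account rests on a few compounds, and the source may have more. Where it says the series, first, only, none or still open, it means among the compounds named here.

Of the compounds shown here, three sharing one core have been measured in a toxicity assay on HUVEC cells (Homo sapiens) for inhibition; on this read-out higher numbers stand for weaker inhibition of growth and lower numbers for stronger inhibition of growth. Here compound 1 (`Cc1ccc(C)c(N2CCN(C(=O)c3oc(C)nc3-c3ccccc3)CC2)c1`) gives 1.73 ug/mL, compound 2 (`Cc1nc(-c2ccccc2)c(C(=O)N2CCN(c3cccc(F)c3)CC2)o1`) gives 1.05 ug/mL, and compound 3 (`COc1cc(OC)cc(N2CCN(C(=O)c3oc(C)nc3-c3ccccc3)CC2)c1`) gives 0.319 ug/mL, the lowest of the three numbers.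

Compound 4 (`Cc1nc(-c2ccccc2)c(C(=O)N2CCN(c3cccc(C#N)c3)CC2)o1`) has 3-cyanophenyl in place of 3,5-dimethoxyphenyl on an amine nitrogen in a ring.

Among the measured compounds shown here, all the measured steps changed this same group. Two of them end at the 3,5-dimethoxyphenyl group of compound 3: a 5.4-fold lower number from compound 1 to compound 3 (0.73 log units; beyond the scatter) and a 3.3-fold lower number from compound 2 to compound 3 (0.52 log units; beyond the scatter). The third, a 1.6-fold lower number from compound 1 to compound 2 (0.22 log units; within the scatter), does not involve that group. The best guide is a 3.3-fold lower number from compound 2 to compound 3 (0.52 log units; beyond the scatter): 3-fluorophenyl, like 3-cyanophenyl, is a phenyl ring bearing a single group. Taking away the 3,5-dimethoxyphenyl group should therefore roughly reverse that step. For the measured compounds named here, no measured compound carries a nitrile, which leaves the forecast loose.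

In this assay a modest move to a higher number is expected, a 2.7-fold higher number from compound 3 to compound 4 (0.43 log units; beyond the scatter). Compound 4 is estimated at 0.85 ug/mL, with an expected range from 0.3 ug/mL to 2.4 ug/mL.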

Compound 4, concentration for 50% growth inhibition: 2.52 ug/mL
Compound 4: middle estimate off by 3.0-fold (0.47 log units), on the low side, and the stated range ends below it.
By their numbers in this assay, from the lowest: compound 3; then compounds 2, 1 and 4 (each within the scatter of the next, the first and the last beyond it).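

In this assay the exchange of fluoro for cyano on an aromatic carbon is a step beyond the scatter (a 2.4-fold higher number from compound 2 to compound 4 (0.38 log units; beyond the scatter)), so phenyl rings bearing a single group need not read alike at this position. The 3-cyanophenyl and 2,5-dimethylphenyl groups cannot be told apart here (a 1.5-fold higher number from compound 1 to compound 4 (0.16 log units; within the scatter)), while the step from the 3,5-dimethoxyphenyl group (a 7.9-fold higher number from compound 3 to compound 4 (0.90 log units; beyond the scatter)) leaves compound 3 alone with the lowest number of the four. Nothing available here explains these differences.

A phenyl ring carrying just one methoxy group would help show whether both methoxy groups are needed for the low number of compound 3. Also open, on these data alone, is how an amine or a carboxylic acid on this phenyl ring would read.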